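Capping the hydroxy end of compound 3

The compounds below may be only part of what the source reports. "The series", "measured", "known", "first", "only" and "open" are said of these compounds alone.

Measured in a functional assay on the whole organism for inhibition, with Rattus norvegicus as the target, read by paw edema, with stated times of 1 h and 3 h; on this read-out lower numbers stand for an effect already at smaller amounts and higher numbers for an effect only at larger amounts of compound:
compound 1 `C/C(=N\OCCC(=O)O)c1ccc(Cl)cc1`: 80 mg/kg
compound 2 `CNC(=O)CO/N=C(\C)c1ccc(Cl)cc1`: 70 mg/kg
compound 3 `C/C(=N\OCCO)c1ccc(Cl)cc1`: 29 mg/kg

Compound 3 has the lowest number of the three. In compound 4 `COC(=O)OCCO/N=C(\C)c1ccc(Cl)cc1`, methoxycarbonyl takes the place of hydrogen on an oxygen on a saturated carbon: methoxycarbonyl in place of hydrogen on an oxygen on a saturated carbon. Within the data shown here, no measured step makes this change. The closest evidence is a 2.8-fold lower number from compound 1 to compound 3 (0.44 log units; beyond the scatter) and a 2.4-fold lower number from compound 2 to compound 3 (0.38 log units; beyond the scatter). Both steps are modest, and neither places a group on that oxygen. A small rise in this assay is therefore expected, with no step beyond the scatter. The expected change is a 1.3-fold higher number from compound 3 to compound 4 (0.12 log units; within the scatter). For compound 4 the estimated value is 38 mg/kg, with an expected range of 17 mg/kg to 85 mg/kg.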

Compound 4, dose for half-maximal effect: 33 mg/kg
Compound 4: middle estimate off by 1.2-fold (0.06 log units), on the high side; low and high end bracket the measured number.
By their numbers in this assay, from the lowest: compounds 3 and 4 (each within the scatter of the next); then compounds 2 and 1 (each within the scatter of the next).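

On the oxygen on a saturated carbon, methoxycarbonyl in place of hydrogen leaves the number in this assay within the scatter (a 1.1-fold higher number from compound 3 to compound 4 (0.06 log units; within the scatter)), so a free hydroxy end is not needed to keep it. The capped end also retains the advantage over the other end groups, with (a 2.1-fold lower number from compound 2 to compound 4 (0.33 log units; beyond the scatter)) and (a 2.4-fold lower number from compound 1 to compound 4 (0.38 log units; beyond the scatter)), both modest but beyond the scatter. No measurement here accounts for these results.

Going by these compounds, whether an acetyl or a methyl group on the same oxygen would give a similar number remains open. So does the effect of an amine in place of the hydroxy.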